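This account rests on a few compounds, and the source may have more. Where it says the series, first, only, none or still open, it means among the compounds named here.

In a functional assay on HCT-116 cells (Homo sapiens) for antiproliferative activity, read by MTT assay, with a stated time of 72 h (a higher number here means a weaker inhibitor, a lower number a stronger inhibitor), compound 1 `COc1ncc(-c2ccc3c(c2)NC(=O)CO3)cc1NS(=O)(=O)c1ccc(F)cc1` gives 24900 nM, compound 2 `COc1ccc(N2C(=O)COc3ccc(-c4cnc(OC)c(NS(=O)(=O)c5ccc(F)cc5)c4)cc32)cc1` gives 13400 nM and compound 3 `COc1ncc(-c2ccc3c(c2)N(c2ccc(Cl)cc2)C(=O)CO3)cc1NS(=O)(=O)c1ccc(F)cc1` gives 19200 nM. Compound 3 thus lies within the scatter of both others, and the three cannot be ranked. Compound 4 `COc1ncc(-c2ccc3c(c2)N(C(C)C)C(=O)CO3)cc1NS(=O)(=O)c1ccc(F)cc1` carries isopropyl in place of 4-chlorophenyl on an amide-type nitrogen in a ring. Among the measured compounds shown here, two measured steps bear on this place, a 1.3-fold lower number from compound 1 to compound 3 (0.11 log units; within the scatter) and a 1.9-fold lower number from compound 1 to compound 2 (0.27 log units; within the scatter), and neither goes beyond the scatter. For the measured compounds named here, no isopropyl analogue has been measured, so the expectation in this assay is no change beyond the scatter. The expected step is a 1.0-fold higher number from compound 3 to compound 4 (0.02 log units; within the scatter). For compound 4 the estimated value is 20000 nM, with an expected range from 9000 nM to 45000 nM.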

Compound 4, half-maximal inhibitory concentration: 19200 nM
Compound 4: middle estimate off by 1.0-fold (0.02 log units), on the high side; the range from low to high includes it.
By their numbers in this assay, from the lowest: compounds 2, 3, 4 and 1 (each within the scatter of the next).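

In this assay, isopropyl in place of 4-chlorophenyl gives no change at the digits printed from compound 3 to compound 4 (within the scatter) and isopropyl in place of 4-methoxyphenyl gives a 1.4-fold higher number from compound 2 to compound 4 (0.16 log units; within the scatter) while isopropyl in place of hydrogen gives a 1.3-fold lower number from compound 1 to compound 4 (0.11 log units; within the scatter) on the amide-type nitrogen. A group with no ring and 3 heavy atoms thus gives a number within the scatter of hydrogen and of both aromatic groups, so this position has not yet separated any of the four compounds. Nothing available here explains this result.

As far as these compounds go, whether a carboxylic acid or a chain ending in an amine on this nitrogen would move the number beyond the scatter remains open.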